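A few compounds are considered here, and "the series" means these few. Any claim that something is new, unique, unknown or untested is made for them only; others in the source may bear on it.

Measured compounds in a functional assay on B16-F10 cells (Mus musculus) for antiproliferative activity, read by ELISA and MTT assay, with a stated time of 48 h; a higher number here means a weaker inhibitor, a lower number a stronger inhibitor:

- compound 1, `O=C(/C=C/c1ccccc1)NS(=O)(=O)c1ccc(Cl)cc1`, gives 2.2 ug/mL
- compound 2, `O=C(/C=C/c1ccccc1)NS(=O)(=O)c1ccc(Br)cc1`, gives 3.9 ug/mL
- compound 3, `O=C(/C=C/c1ccc(F)cc1)NS(=O)(=O)c1ccc(Cl)cc1`, gives 2.6 ug/mL

Three compounds are measured and one, compound 4 with structure `O=C(/C=C/c1ccc(F)cc1)NS(=O)(=O)c1ccc(Br)cc1`, is not. Compound 2 differs from compound 1 by bromo in place of chloro on an aromatic carbon, and the step made there is a 1.8-fold higher number from compound 1 to compound 2 (0.25 log units; within the scatter). Compound 3 differs from compound 1 by fluoro in place of hydrogen on an aromatic carbon, with the step of a 1.2-fold higher number from compound 1 to compound 3 (0.07 log units; within the scatter). Compound 4 differs from compound 3 by bromo in place of chloro on an aromatic carbon. The change from compound 3 to compound 4 is the same as the change from compound 1 to compound 2: what leaves, what enters and the place around it are described in the same words for both pairs, so the two changes are taken as the same change, carried out on two cores that differ only as described for compound 1 and compound 3.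

With a single earlier instance of this change, the expectation for compound 4 rests on it alone. Within the data shown here, the step from compound 3 to compound 4 is expected to be about as large as the earlier one, a 1.7-fold higher number from compound 3 to compound 4 (0.24 log units; within the scatter), because the step of a 1.8-fold higher number from compound 1 to compound 2 (0.25 log units; within the scatter) is the only measured example and the surroundings of the change are the same. On that basis compound 4 is estimated at 4.5 ug/mL in this assay, with a likely range from 2.5 ug/mL to 8 ug/mL.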

Compound 4, half-maximal inhibitory concentration: 2.8 ug/mL
Estimate against measurement, compound 4: 1.6-fold (0.21 log units) above; low and high end bracket the measured number.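

In this assay, bromo in place of chloro on an aromatic carbon gives a 1.1-fold higher number from compound 3 to compound 4 (0.03 log units; within the scatter), and this step agrees with its earlier instance: the same change on two cores in this assay, a 1.8-fold higher number (0.25 log units; within the scatter) from compound 1 to compound 2 and a 1.1-fold higher number (0.03 log units; within the scatter) from compound 3 to compound 4, 1.6-fold (0.22 log units) apart, within the scatter of two such steps. With bromo in place of chloro on the sulfonyl-bearing ring, fluoro in place of hydrogen on an aromatic carbon gives a 1.4-fold lower number from compound 2 to compound 4 (0.14 log units; within the scatter), and this step also agrees with its earlier instance: the same change on two cores in this assay, a 1.2-fold higher number (0.07 log units; within the scatter) from compound 1 to compound 3 and a 1.4-fold lower number (0.14 log units; within the scatter) from compound 2 to compound 4, 1.6-fold (0.22 log units) apart, within the scatter of two such steps. Both changes therefore carry between these cores with no difference that can be told from the scatter, but all four steps are themselves within the scatter, and these compounds show neither that either change moves the number nor that a change with a step beyond the scatter would carry in the same way.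

The compounds shown hold only chloro, bromo, fluoro and hydrogen at the changed places, leaving open whether a methoxy group, a nitro group or an amine there would give a step beyond the scatter. Also open, going by these compounds, is how a carboxylic acid or a longer chain on the shared core would behave, and whether these steps hold in any other cell line.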